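Phenyl to benzyl on a saturated ring carbon

This account rests on a few compounds, and the source may have more. Where it says the series, first, only, none or still open, it means among the compounds named here.

Of the compounds shown here, two have numbers so far. In a functional assay on HCT-116 cells (Homo sapiens) for inhibition, read by ATP content, with a stated time of 72 h (a higher number here means a weaker inhibitor, a lower number a stronger inhibitor), compound 1 (`Nc1ccccc1NC(=O)c1ccc(CNC2=N[C@@H](Cc3ccccc3)CS2)cc1`) gives 1950 nM and compound 2 (`Nc1ccccc1NC(=O)c1ccc(CNC2=NC(=O)C(c3ccccc3)N2)cc1`) gives 18200 nM on a different core. Compound 2 therefore holds the higher of the two numbers, and its gap to compound 1 lies beyond the scatter, which makes it the weaker inhibitor of the pair.

Compound 3 (`Nc1ccccc1NC(=O)c1ccc(CNC2=NC(=O)C(Cc3ccccc3)N2)cc1`) departs from compound 2 in one place, with benzyl in place of phenyl on a saturated ring carbon. Going by the values given here, no measured pair yet shows this change on a single core, so the expectation rests on thin evidence. Compound 1 also carries a benzyl group, and its 1950 nM in this assay offers the only hint, weakened by its different core. A modest move towards a lower number is therefore expected, with only part of the gap to compound 1 closed. The expected step lies close to the edge of the scatter (a 2.3-fold lower number from compound 2 to compound 3 (0.36 log units; beyond the scatter)) and remains uncertain. For compound 3 the estimated value is 8000 nM (expected range 2500 nM to 22000 nM).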

Compound 3, half-maximal inhibitory concentration: 16600 nM
For compound 3 the middle estimate is 2.1-fold (0.32 log units) below the measured one; low and high end bracket the measured number.
By their numbers in this assay, from the lowest: compound 1; then compounds 3 and 2 (each within the scatter of the next).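

In this assay, the step for benzyl in place of phenyl on a saturated ring carbon is a 1.1-fold lower number from compound 2 to compound 3 (0.04 log units; within the scatter), so compounds 2 and 3 stand level. Going by these compounds alone, this is the first pair that reads this change on a single core, and on the shared core it gives a flat result at this position: phenyl and benzyl cannot be told apart by their numbers, and both compounds sit in the same range. No supporting data are available to account for this flat step.

Going by these compounds, it remains open whether a different kind of group on this ring carbon, such as an amine, a carboxylic acid or a longer chain such as phenethyl, would move the number beyond the scatter of compounds 2 and 3. Also open is whether benzyl in place of phenyl would read the same way on the core of compound 1, since the compounds shown offer no pair for this change on that core.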